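This account rests on a few compounds, and the source may have more. Where it says the series, first, only, none or still open, it means among the compounds named here.

The compounds here share one core and are checked in an ADME assay on HCT-116 cells (Homo sapiens) for cytotoxicity, read by CellTiter-Glo, with a stated time of 72 h; on this read-out lower numbers stand for stronger inhibition and higher numbers for weaker inhibition. Compound 1 `Cc1cc(C)cc(-c2cccc(S(=O)(=O)N3CCC(N4CCC(C)CC4)CC3)c2)c1` carries a 3,5-dimethylphenyl group, and in this assay compound 1 gives > 5000 nM, which is a limit of the assay rather than a measured number. Compound 2 `CC1CCN(C2CCN(S(=O)(=O)c3ccc(Br)cc3OC(F)(F)F)CC2)CC1` reaches only > 5000 nM, again a limit. Compound 3 `CC1CCN(C2CCN(S(=O)(=O)c3cccc4ccccc34)CC2)CC1` reaches only > 10000 nM, also a limit. Compound 1 thus stands together with the others: the limit of > 5000 nM in this assay, at which 2 of the 3 values shown sit, while (the limit of > 10000 nM in this assay, at which 1 of the 3 values shown sits). No measured number separates any of these three from one another.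

Compound 4 `CC1CCN(C2CCN(S(=O)(=O)c3cccc(N)c3)CC2)CC1` differs from compound 1 in one place: amino in place of 3,5-dimethylphenyl on an aromatic carbon. For the measured compounds named here, since every measured compound stops at a limit, there is no measured step to draw on, and nothing among the three suggests a change beyond the usual scatter of this assay. The step that the limit leaves unreadable from compound 1 to compound 4 is therefore expected to be small or absent. Compound 4 is expected to give about 8000 nM, within 3000 nM to 30000 nM, and most likely to be reported once more only as a limit.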

Compound 4, half-maximal inhibitory concentration: > 5000 nM
Compound 4: a limit, no number; the forecaster's own chance of this, stated with the estimate: 85%; the middle value is on the limit's open side.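

Compound 1 and compound 4 are both reported only as limits, not as measured numbers, so the step between them cannot be read. The compounds shown leave open at what concentration, if any, each one inhibits these cells, and whether amino in place of 3,5-dimethylphenyl changes that.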